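A chlorine swap on a compound at the assay limit

A few compounds are considered here, and "the series" means these few. Any claim that something is new, unique, unknown or untested is made for them only; others in the source may bear on it.

Compounds measured so far in a functional assay on HCT-15 cells (Homo sapiens) for cytotoxicity, read by ELISA, with a stated time of 4 days (a higher number here means a weaker inhibitor, a lower number a stronger inhibitor), each value a limit:
Compound 1 (`Clc1ccc(-c2cc(-c3ccco3)nc(-c3ccc(Cl)s3)c2)o1`) gives > 50000 nM
Compound 2 (`Cc1ccc(-c2cc(-c3ccc(Cl)o3)cc(-c3ccc(Cl)s3)n2)cc1`) gives > 50000 nM

Compound 2 stands at a limit and has no number (> 50000 nM). The evidence so far is the limit of > 50000 nM in this assay, at which 2 of the 2 values shown sit, and nothing finer. In compound 3 (`Clc1cccc(-c2cc(-c3ccc(Cl)o3)cc(-c3ccc(Cl)s3)n2)c1`), 3-chlorophenyl takes the place of 4-methylphenyl on an aromatic carbon, next to the ring nitrogen (3-chlorophenyl in place of 4-methylphenyl on an aromatic carbon). Among the measured compounds shown here, the only measured step that bears on this change is a step that the two limits leave unreadable from compound 1 to compound 2, in which 4-methylphenyl took the place of furan-2-yl. That step gives neither a size nor a direction. No measured size therefore supports a step beyond the scatter in this assay, and no direction is expected. The expected step is an at least 1.1-fold lower number from compound 2 to compound 3 (0.04 log units; that floor lies within the scatter), and it rests on no measured number. For compound 3 the estimated value is 45000 nM, with an expected range from 10000 nM to 100000 nM, and the assay may well report only a limit.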

Compound 3, half-maximal inhibitory concentration: > 50000 nM
Compound 3: no number, only a limit; the forecaster's own chance of this, stated with the estimate: 65%; at least 1.1-fold (0.04 log units) between middle value and limit.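

In this assay compound 3 gives > 50000 nM, which is a limit and not a number. No step among compound 1, compound 2 and compound 3 can be read, since all three stand at the same limit: the limit of > 50000 nM in this assay, at which 3 of the 3 values shown sit.

The compounds shown leave open how these three differ in this assay and whether any change to the shared core would give a measurable value.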